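A few compounds are considered here, and "the series" means these few. Any claim that something is new, unique, unknown or untested is made for them only; others in the source may bear on it.

Measured so far:
compound 1, `CCn1c(-c2cnc(C)nc2)nc2c(N[C@H]3CCN(C(=O)C4CC(F)(F)C4)C3)ncnc21`: 0.9 L/kg
compound 2, `CCn1c(-c2ccc(C(F)(F)F)nc2)nc2c(O[C@H]3CCN(C(=O)c4cocn4)C3)ncnc21`: 0.3 L/kg

In an ADME assay (Rattus norvegicus, strain Wistar Han) for pharmacokinetics (a higher number here means that more of the compound sits outside the plasma, a lower number that more of the compound stays in the plasma), compound 2 gives 0.3 L/kg, the lowest of the two numbers shown. Compound 1 gives 0.9 L/kg in this assay, a higher number, and the gap between the two lies beyond the usual scatter. Compound 1 and compound 2 differ in several places at once, so the pair says only what its two values show and no single change can be held responsible for the gap.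

Compound 3, `CCn1c(-c2ccc(C(F)(F)F)nc2)nc2c(O[C@H]3CCN(C(=O)N4CC(OC)C4)C3)ncnc21`, has not yet been measured in this assay. It follows from compound 2 by one change on the carbonyl carbon that sits on the amide-type nitrogen in the ring: 3-methoxyazetidin-1-yl in place of 1,3-oxazol-4-yl on a carbonyl carbon. Within the data shown here, no step between measured compounds isolates a change of this kind, so the expectation rests on the value of compound 2 alone. A small upward step is expected in this assay, of a size that stays within the usual scatter: the expected step is a 1.3-fold higher number from compound 2 to compound 3 (0.12 log units; within the scatter). Compound 3 is therefore estimated at 0.4 L/kg in this assay, with a range from 0.2 L/kg to 0.8 L/kg.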

Compound 3, volume of distribution: 0.2 L/kg
Compound 3: middle estimate off by 2.0-fold (0.30 log units), on the high side; measured number inside the range.
By their numbers in this assay, from the lowest: compounds 3 and 2 (each within the scatter of the next); then compound 1.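

Among these compounds, on the carbonyl carbon whose other neighbour is the amide-type nitrogen in a ring, 3-methoxyazetidin-1-yl in place of 1,3-oxazol-4-yl gives a 1.5-fold lower number from compound 2 to compound 3 (0.18 log units; within the scatter) in this assay, the first step that isolates a change in one place. The exchange replaces a five-membered aromatic ring with a four-membered non-aromatic ring, with no hydrogen-bond donors and no net charge on either side, yet the read-out does not separate the two compounds, so at this position these two groups are interchangeable as far as this measurement can tell. No measurement is available that bears on what lies behind this result.

Still open, on these data alone, is whether a group of another kind on the same carbonyl carbon, such as a carboxylic acid or a dimethylamino group carried on the azetidine in place of the methoxy, would give a step beyond the scatter. Also open, as far as these compounds go, is whether the same exchange of 1,3-oxazol-4-yl for 3-methoxyazetidin-1-yl would give a step of similar size with the other parts of compound 1 in place.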